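Carbamoyl in place of 1H-imidazol-2-yl on the side chain

The source may report more compounds than this note shows. Statements on the series, on what has been measured and on what is new or still open speak of the compounds shown alone.

Measured compounds and their numbers:
compound 1, `CC(C)C(Cc1ncc[nH]1)c1ccc(-c2ccc3cccc(F)c3c2)[nH]c1=O`, gives 11 nM
compound 2, `CC(C)C(c1ncco1)c1ccc(-c2ccc3cccc(F)c3c2)[nH]c1=O`, gives 24 nM
compound 3, `CC(C)C(Cc1nnn[nH]1)c1ccc(-c2ccc3cccc(F)c3c2)[nH]c1=O`, gives 34 nM

In an assay on CHO cells for displacement of a labelled ligand from prostaglandin E2 receptor EP3 subtype (Homo sapiens), read by radioligand binding (a higher number here means a weaker inhibitor, a lower number a stronger inhibitor), compound 1 stands lowest of the three numbers. The two steps away from it are a 2.2-fold higher number from compound 1 to compound 2 (0.34 log units; beyond the scatter) and a 3.1-fold higher number from compound 1 to compound 3 (0.49 log units; beyond the scatter); each is beyond the scatter yet modest in size. Between the other two compounds the difference is a 1.4-fold higher number from compound 2 to compound 3 (0.15 log units; within the scatter), so the three sit within a narrow band.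

Compound 4, `CC(C)C(CC(N)=O)c1ccc(-c2ccc3cccc(F)c3c2)[nH]c1=O`, is not yet measured. Its change from compound 1 reads (carbamoyl in place of 1H-imidazol-2-yl on a saturated chain carbon, two bonds along the chain from an aromatic carbon). The measured steps that bear on it are the two that alter the same side chain of compound 1: both keep a five-membered aromatic ring at that position and both cost a modest amount. For the measured compounds named here, no measured compound removes the ring altogether, so the expectation for compound 4 rests on the direction those two steps share rather than on a close precedent. A modest upward move from compound 1 is expected, of about a 3.2-fold higher number from compound 1 to compound 4 (0.50 log units; beyond the scatter), with wider uncertainty than for a ring-to-ring swap.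

Compound 4 is therefore expected to give 35 nM, in a range from 10 nM to 120 nM.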

Compound 4, inhibition constant: 5 nM
Beside the measured number, compound 4's estimate is 7.0-fold (0.85 log units) above it, and the stated range ends above it.
By their numbers in this assay, from the lowest: compound 4; then compound 1; then compounds 2 and 3 (each within the scatter of the next).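

In this assay, the five-membered aromatic ring proves dispensable at this position: carbamoyl in place of 1H-imidazol-2-yl, on a saturated chain carbon, two bonds along the chain from an aromatic carbon, gives a 2.2-fold lower number from compound 1 to compound 4 (0.34 log units; beyond the scatter), with 3 heavy atoms entering where 5 leave. For the compounds shown here, the gain is larger against the other two side chains, at a 6.8-fold lower number from compound 3 to compound 4 (0.83 log units; beyond the scatter) and a 4.8-fold lower number from compound 2 to compound 4 (0.68 log units; beyond the scatter), so compound 4 now holds the lowest number of the four and the narrow band of the earlier compounds no longer holds for the series. The hydrogen-bond donor and acceptor counts are the same for the leaving and entering groups, and nothing available here accounts for the gain.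

It remains open which parts of the carbamoyl carry the result, as the compounds shown include no methyl-substituted amide, carboxylic acid or methyl ester at this place. Going by these compounds alone, also open is how far the chain length matters, as they include no longer chain ending in carbamoyl and no compound with the carbamoyl attached directly to the saturated chain carbon bound to the aromatic carbon.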